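The source may hold more compounds than are shown below. What is called first, only, known or untested is meant among the compounds shown, and "the series" means these compounds.

In an assay on HEK293 cells for inhibition of Steryl-sulfatase (Homo sapiens), tested at 1 uM (on this read-out lower numbers stand for a weaker effect and higher numbers for a stronger effect at the one concentration tested), the three measured compounds gave these numbers:

Compound 1 `CCN(Cc1cccc(Br)c1)c1ccc(C(=O)N2CCc3ccc(OS(N)(=O)=O)cc3C2)cc1`: 97.2%
Compound 2 `NS(=O)(=O)Oc1ccc2c(c1)CN(C(=O)c1cccc(N3CCC(N4CCCCC4)CC3)c1)CC2`: 8%
Compound 3 `CCN(Cc1cccc(Br)c1)c1cccc(C(=O)N2CCc3ccc(OS(N)(=O)=O)cc3C2)c1`: 24.9%

Compound 1 stands highest of the three. Its nearest neighbour on the numbers is compound 3, whose value lies well below it, beyond the scatter; compound 2 lies furthest away, also beyond the scatter. No single-point comparison between any two of these measured compounds is available, so the three values can only be read side by side.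

Compound 4 `CCCN(Cc1ccccc1)c1ccc(C(=O)N2CCc3ccc(OS(N)(=O)=O)cc3C2)cc1` has not yet been measured. It differs from compound 1 in one place: benzyl(propyl)amino in place of (3-bromobenzyl)(ethyl)amino on an aromatic carbon. The change sits on an aromatic carbon, para to a large group, and keeps the rest of the shared core of compound 1 intact. Among the measured compounds shown here, nothing among the measured compounds isolates this exchange, so the expected step rests on the strong reading of compound 1 97.2% alone. Compound 4 is expected to remain a strong inhibitor, with a step of a number 12.2 percentage points lower from compound 1 to compound 4 (beyond the scatter) that is small and most likely downward, near or just beyond the scatter. The estimate for compound 4 is 85%, within a range from 60% to 98%.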

Compound 4, a percentage reported as inhibition, at one concentration (the size of the read-out at that concentration, not a potency): 94.3%
Beside the measured number, compound 4's estimate is 9.3 percentage points below it, within the range that was stated.
By their numbers in this assay, from the lowest: compound 2; then compound 3; then compounds 4 and 1 (each within the scatter of the next).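

In this assay, among the compounds shown here, this is the first comparison in the set that isolates one place, and exchanging (3-bromobenzyl)(ethyl)amino for benzyl(propyl)amino on an aromatic carbon, para to a large group, gives a number 2.9 percentage points lower from compound 1 to compound 4 (within the scatter). With the shared core intact, this place therefore accepts both groups without a difference that can be told from the scatter, and the bromine of compound 1 is not needed for a strong reading, since compound 4 carries none. Nothing at hand gives a reason for this result.

The exchange removes the bromine and replaces ethyl with propyl in one step, so the compounds shown do not separate these two changes. Going by these compounds, it also remains open whether a longer chain than propyl, or an amine or a carboxylic acid on the benzyl group, would keep the reading this strong.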